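Phenyl for Methyl on the Ring of Compound 3

This account rests on a few compounds, and the source may have more. Where it says the series, first, only, none or still open, it means among the compounds named here.

Measured compounds:
compound 1, `CC/N=C(\S)CCn1nc(-c2ccccc2)ccc1=O`, 50.3%
compound 2, `Cc1ccc(=O)n(CCCCCC(=N)S)n1`, 36.6%
compound 3, `CC1=NN(C(C)CC(=N)S)C(=O)CC1`, 17.4%

In a functional assay on the whole organism (stomach) for inhibition, with Rattus norvegicus as the target, at a dose of 100 mg/kg by the intraduodenal route (a lower number here means less inhibition, a higher number more inhibition at the dose given (going by the name of the read-out)), compound 3 gives 17.4%, the lowest of the three numbers. Its nearest neighbour is compound 2 with 36.6%, a gap beyond the scatter, and compound 1 stands furthest from it with 50.3%, also beyond the scatter. Compound 4, `CC(CC(=N)S)N1N=C(c2ccccc2)CCC1=O`, has not yet been measured in this assay. It differs from compound 3 in one place: phenyl in place of methyl on a carbon with a double bond to nitrogen.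

Among the measured compounds shown here, no measured pair shows this change on its own. Compound 1 carries a phenyl on its ring and compound 2 a methyl, and compound 1 gives the higher number of the two, but these compounds differ in several other places as well, so the comparison gives only a loose hint. On that hint the step of a number 12.6 percentage points higher from compound 3 to compound 4 (beyond the scatter) is expected to be an increase of moderate size, with a wide range on either side. Compound 4 is therefore estimated at 30%, between 12% and 52%.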

Compound 4, a percentage reported as inhibition, in the whole organism at one dose (the size of the read-out at that dose, not a potency): 9.2%
Compound 4: the middle estimate sits 20.8 percentage points above what was measured, and the stated range ends above it.
By their numbers in this assay, from the lowest: compounds 4 and 3 (each within the scatter of the next); then compound 2; then compound 1.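

Among the compounds shown here, this pair gives the first direct reading of the change: in this assay, phenyl in place of methyl on a carbon with a double bond to nitrogen gives a number 8.2 percentage points lower from compound 3 to compound 4 (within the scatter). The position thus takes the six carbons and aromatic ring of phenyl in place of the single carbon of methyl with no step beyond the scatter, so in this core the change alone does not separate the two compounds. No measurement shown here bears on why the two numbers stand so close.

From the compounds shown here alone, whether an amine, a carboxylic acid or a longer chain at this carbon would read the same remains open. So does whether phenyl for methyl would give a similar step in the cores of compound 1 and compound 2.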